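Swapping the Pyridine for a Thiophene on the Amide Arm

The source may hold more compounds than are shown below. What is called first, only, known or untested is meant among the compounds shown, and "the series" means these compounds.

Of the compounds shown here, three sharing one core have been measured in a physicochemical assay for lipophilicity, using the shake flask method, in phosphate buffer, measured as octanol-water partition, at pH 7.4; a higher number here means a more lipophilic compound, a lower number a more polar compound. Compound 1 `COc1cc(-c2cc(C(=O)O)c3ccccc3n2)ccc1OCC(=O)Nc1cccc(Cl)c1` gives 2.3, compound 2 `COc1cc(-c2cc(C(=O)O)c3ccccc3n2)ccc1OCC(=O)Nc1cccc(C(F)(F)F)c1` gives 1.3, and compound 3 `COc1cc(-c2cc(C(=O)O)c3ccccc3n2)ccc1OCC(=O)NCc1cccnc1` gives -0.8, the lowest of the three. The steps toward compound 3 were both large: a number 3.10 log units lower from compound 1 to compound 3 (beyond the scatter) and a number 2.10 log units lower from compound 2 to compound 3 (beyond the scatter), each time when the (pyridin-3-yl)methyl group entered on the amide-type nitrogen. By comparison the step of a number 1.00 log units lower from compound 1 to compound 2 (beyond the scatter) was modest.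

Compound 4 `COc1cc(-c2cc(C(=O)O)c3ccccc3n2)ccc1OCC(=O)NCc1cccs1` keeps that methylene link and changes only the ring on it: thiophen-2-yl in place of pyridin-3-yl on a saturated chain carbon bound to an amide-type nitrogen. For the measured compounds named here, no measured step covers this exact swap; the nearest information is that compound 3, carrying the pyridin-3-yl ring, sits far beneath compounds 1 and 2 in this assay. The change to compound 4 removes that ring, so a step upward is expected, of a size between modest and large: a number 1.30 log units higher from compound 3 to compound 4 (beyond the scatter). The value of compound 4 in this assay is therefore estimated at 0.5, within a range from -0.3 to 1.3.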

Compound 4, distribution coefficient: 0
For compound 4 the middle estimate is 0.50 log units above the measured one; the measured number falls inside the stated range.
By their numbers in this assay, from the lowest: compound 3; then compound 4; then compound 2; then compound 1.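

In this assay, the ring carried on the methylene link affects the number by itself, with the link unchanged: thiophen-2-yl in place of pyridin-3-yl gives a number 0.80 log units higher from compound 3 to compound 4 (beyond the scatter). The swap closes only part of the distance to the compounds whose amide nitrogen carries a substituted phenyl ring directly, as (thiophen-2-yl)methyl still gives a number 1.30 log units lower from compound 2 to compound 4 (beyond the scatter) and a number 2.30 log units lower from compound 1 to compound 4 (beyond the scatter). Nothing at hand explains why this ring change moves the number as it does.

Compounds 1 and 2 differ from compound 4 in both the link and the ring. These data do not show how much of the remaining distance goes with each. A benzyl group on the amide nitrogen, with a phenyl ring on the same methylene link, would separate the two, and a longer chain would test the link further.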